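The source may hold more compounds than are shown below. What is called first, only, known or untested is meant among the compounds shown, and "the series" means these compounds.

Measured in an ADME assay on HEK293 cells (Homo sapiens) for cytotoxicity, read by ATP content, with a stated time of 6 h (a lower number here means that less compound is tolerated, a higher number that more compound is tolerated), each entry a limit and not a number:

- Compound 1 `CCCCNc1nc(N)nc2ccn(Cc3ccccn3)c12`: > 24000 nM
- Compound 2 `CCOCCNc1nc(N)nc2ccn(Cc3ccccn3)c12`: > 24000 nM
- Compound 3 `Cc1nc(CNc2nc(N)nc3ccn(Cc4ccccn4)c23)cs1`: > 24000 nM

All three compounds share one limit, as the limit of > 24000 nM in this assay, at which 3 of the 3 values shown sit, shows, so compound 3 has no number to start from. Compound 4 `Cc1coc(CNc2nc(N)nc3ccn(Cc4ccccn4)c23)n1` differs from it as follows: 4-methyl-1,3-oxazol-2-yl in place of 2-methyl-1,3-thiazol-4-yl on a saturated chain carbon bound to a nitrogen on an aromatic ring. In words, this is 4-methyl-1,3-oxazol-2-yl in place of 2-methyl-1,3-thiazol-4-yl on a saturated chain carbon bound to a nitrogen on an aromatic ring.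

Two measured changes at this place bear on it: a step that the two limits leave unreadable from compound 1 to compound 3 and a step that the two limits leave unreadable from compound 2 to compound 3. Neither has a size that can be read, but neither brought a number inside the measured range. No step beyond the usual scatter is therefore expected in this assay, and compound 4 will probably again return only a limit. The estimated change is a step that the limit leaves unreadable from compound 3 to compound 4. For compound 4 the estimate is 28000 nM, with an expected range from 14000 nM to 50000 nM.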

Compound 4, half-maximal cytotoxic concentration: > 24000 nM
Compound 4: only a limit was reported (the forecaster's own chance of this, stated with the estimate: 85%); the middle value lies beyond the limit too.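

Within the data shown here, compound 1, compound 2, compound 3 and compound 4 all return only a limit in this assay, so no step among them can be read: the limit of > 24000 nM in this assay, at which 4 of the 4 values shown sit. The compounds shown leave open the actual half-maximal cytotoxic concentration of each, and so whether these four differ at all.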